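Aryl swap on the shared core: two limits, one estimate

The source may report more compounds than this note shows. Statements on the series, on what has been measured and on what is new or still open speak of the compounds shown alone.

Measured so far:
Compound 1 `CCOc1ccc(-c2cc(=O)c3c(o2)C(CC)(CC)C(=O)C(CC)=C3O)cc1` gives > 52.4 uM in a functional assay on KB cells (Homo sapiens) for antiproliferative activity, read by sulforhodamine B assay, with a stated time of 3 days; a lower number here means that less compound is needed, a higher number that more compound is needed for the effect.
Compound 2 `CCC1=C(O)c2c(oc(-c3cccc(OC(F)(F)F)c3)cc2=O)C(CC)(CC)C1=O` gives > 47.4 uM in this assay.

Both readings are limits of the assay, not numbers. For compound 1 the reading sits at the limit of > 52.4 uM in this assay, at which 1 of the 2 values shown sits. For compound 2 the reading sits at the limit of > 47.4 uM in this assay, at which 1 of the 2 values shown sits. Compound 1 therefore cannot be placed on a scale against compound 2: both values are limits and neither is ordered against the other.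

Compound 3 `CCC1=C(O)c2c(oc(-c3ccccc3OC)cc2=O)C(CC)(CC)C1=O` is not yet measured. It differs from compound 1 by 2-methoxyphenyl in place of 4-ethoxyphenyl on an aromatic carbon. For the measured compounds named here, no step between measured compounds is on hand, so the size of change in this assay for 2-methoxyphenyl in place of 4-ethoxyphenyl cannot be drawn from a measured pair. With both measured values resting at limits, the expectation is for no shift beyond the scatter, that is, a reading again at or close to the limit.

Compound 3 is expected to give 50 uM, with a range of 20 uM to 100 uM. The step from compound 1 to compound 3 that this estimate means is an at least 1.0-fold lower number from compound 1 to compound 3 (0.02 log units; that floor lies within the scatter), expected to be within the scatter.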

Compound 3, concentration for half-maximal effect: 40.8 uM
The estimate for compound 3 lay 1.2-fold (0.09 log units) above the measured number; the range from low to high includes it.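

With 2-methoxyphenyl in place of 4-ethoxyphenyl on the aromatic carbon next to the ring oxygen, the series gains its first reading that is a number and not a limit: in this assay compound 3 gives 40.8 uM. The reading for compound 1 remains a limit of the assay: the limit of > 52.4 uM in this assay, at which 1 of the 3 values shown sits. The change therefore comes to an at least 1.2-fold lower number from compound 1 to compound 3 (0.10 log units; that floor lies within the scatter), which fixes only a floor for the step, and that floor gives no evidence of a real shift at this position, though it does show that a measurable reading is possible with the shared core and this aryl swap.

The groups 2-methoxyphenyl and 4-ethoxyphenyl differ both in where the ether sits on the aryl ring and in the length of its chain, and this pair does not separate the two. Also open, going by these compounds, is how an aryl ring carrying an amine, a carboxylic acid or a longer alkoxy chain at this position would read in this assay, and whether any such group would move the number clearly beyond the scatter.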